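Swapping Chloro for Methoxy on an Inactive Core

The source may hold more compounds than are shown below. What is called first, only, known or untested is meant among the compounds shown, and "the series" means these compounds.

Compound 1 `O=C(O)CC(Cc1nc2cc(Cl)ccc2[nH]1)c1ccc(Cl)cc1` was tested in an assay on isolated protein for inhibition of protein kinase C zeta type (Homo sapiens), read by 33P incorporation, tested at 50 uM (on this read-out lower numbers stand for a weaker effect and higher numbers for a stronger effect at the one concentration tested), where compound 1 gives 0%. Two close relatives were measured alongside it: compound 2 `Cc1ccc2[nH]c(CC(CC(=O)O)c3ccc(Cl)cc3)nc2c1` gives 0%, and compound 3 `CCc1ccc2[nH]c(CC(CC(=O)O)c3ccc(Cl)cc3)nc2c1` gives 0%. The step of no change at the digits printed from compound 1 to compound 2 (within the scatter) and the step of no change at the digits printed from compound 1 to compound 3 (within the scatter) show that exchanging the chloro on the shared core for methyl or ethyl produces nothing beyond the scatter, and the step of no change at the digits printed from compound 2 to compound 3 (within the scatter) is equally flat. Compound 1 thus stands level with compounds 2 and 3.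

Compound 4 `COc1ccc2[nH]c(CC(CC(=O)O)c3ccc(Cl)cc3)nc2c1` differs from compound 1 by methoxy in place of chloro on an aromatic carbon. The two steps that bear on this change, no change at the digits printed from compound 1 to compound 2 (within the scatter) and no change at the digits printed from compound 1 to compound 3 (within the scatter), both replaced the same chloro with a carbon group and each came out flat. Going by the values given here, no measured step has placed an oxygen-containing group at this carbon, so the expectation rests on that resemblance alone. Compound 4 is therefore expected to give 0%, within a range from -10% to 15%, an expected step of no change at the digits printed from compound 1 to compound 4 (within the scatter) that stays within the scatter.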

Compound 4, a percentage reported as inhibition, at one concentration (the size of the read-out at that concentration, not a potency): 0%
The estimate for compound 4 equals the measured number at the digits printed, and the stated range covers the measured number.
By their numbers in this assay, from the lowest: compounds 1, 2, 3 and 4 (each within the scatter of the next).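

In this assay, methoxy in place of chloro on this aromatic carbon gives no change at the digits printed from compound 1 to compound 4 (within the scatter), so the flat picture seen with the carbon groups now extends to a group that contains oxygen and carries a hydrogen-bond acceptor. The comparisons with the carbon groups agree: methoxy in place of methyl gives no change at the digits printed from compound 2 to compound 4 (within the scatter), and methoxy in place of ethyl gives no change at the digits printed from compound 3 to compound 4 (within the scatter). No measurement available here offers an explanation for this flat result.

Going by these compounds alone, because all four compounds stand level with no measurable inhibition, the series cannot show whether this position can influence the read-out at all, since no active compound is available as a reference. From the compounds shown here alone, whether an amine or a longer chain on this aromatic carbon would produce any inhibition remains open.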